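A Hydroxy Group Added to a Weak Growth Inhibitor

This account rests on a few compounds, and the source may have more. Where it says the series, first, only, none or still open, it means among the compounds named here.

In a functional assay on SiHa cells (Homo sapiens) for inhibition, read by sulforhodamine B assay (a higher number here means a weaker inhibitor of growth, a lower number a stronger inhibitor of growth), compound 1 (`FC(F)(F)c1ccc(-c2ccc(-c3ccc(-c4nc5ccccc5[nH]4)cc3)cc2)cc1`) gives 100000 nM, the highest of the three numbers measured, which makes it the weakest inhibitor of growth among them. Compound 2 (`FC(F)(F)Oc1ccc(-c2ccc(-c3ccc(-c4nc5ccccc5[nH]4)cc3)cc2)cc1`) gives 38400 nM, and compound 3 (`Oc1ccc(-c2ccc(-c3ccc(-c4nc5ccccc5[nH]4)cc3)cc2)cc1`) gives 33300 nM. The measured steps are a 2.6-fold lower number from compound 1 to compound 2 (0.42 log units; beyond the scatter) and a 3.0-fold lower number from compound 1 to compound 3 (0.48 log units; beyond the scatter), both modest, while a 1.2-fold lower number from compound 2 to compound 3 (0.06 log units; within the scatter) shows no separation between the last two. Compound 4 (`Oc1cccc2[nH]c(-c3ccc(-c4ccc(-c5ccc(C(F)(F)F)cc5)cc4)cc3)nc12`) keeps the trifluoromethyl group of compound 1 and differs by hydroxy in place of hydrogen on an aromatic carbon, turning 1H-benzimidazol-2-yl into 4-hydroxy-1H-benzimidazol-2-yl. Among the measured compounds shown here, no measured step makes this exact change. The closest guide is compound 3, which also carries a hydroxy, though at a different place, with a 3.0-fold lower number from compound 1 to compound 3 (0.48 log units; beyond the scatter). A modest step to a lower number in this assay is therefore expected, and the estimate means a 2.5-fold lower number from compound 1 to compound 4 (0.40 log units; beyond the scatter). The expected value for compound 4 is 40000 nM, with an estimated range from 12000 nM to 100000 nM.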

Compound 4, concentration for 50% growth inhibition: 3720 nM
Beside the measured number, compound 4's estimate is 11-fold (1.03 log units) above it; measured number outside the range, below it.
By their numbers in this assay, from the lowest: compound 4; then compounds 3 and 2 (each within the scatter of the next); then compound 1.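

In this assay, turning 1H-benzimidazol-2-yl into 4-hydroxy-1H-benzimidazol-2-yl gives a 27-fold lower number from compound 1 to compound 4 (1.43 log units; beyond the scatter) as a large step, whereas replacing the trifluoromethyl group with hydroxy gave only a modest one (a 3.0-fold lower number from compound 1 to compound 3 (0.48 log units; beyond the scatter)). A single hydroxy in place of hydrogen, on an aromatic carbon of the fused system, therefore moves the number further than any earlier change to the trifluoromethyl group did. Nothing available explains why the number falls so far with this change.

The compounds shown leave open whether a hydroxy is needed at this carbon, or whether an amine or a methoxy there would give a similar step. They also leave open whether the step would hold with the hydroxy or trifluoromethoxy of compound 3 and compound 2 in place of trifluoromethyl.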